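Methoxy in place of methyl on an aromatic carbon

A few compounds are considered here, and "the series" means these few. Any claim that something is new, unique, unknown or untested is made for them only; others in the source may bear on it.

In a functional assay on HCT-116 cells (Homo sapiens) for inhibition, read by MTT assay, with a stated time of 2 days (a lower number here means a stronger inhibitor of growth, a higher number a weaker inhibitor of growth), compound 1 (`Nc1ccccc1NC(=O)c1ccc(NCC(=O)Nc2cccc([N+](=O)[O-])c2)cc1`) gives 1100 nM. Compound 2 (`Cc1ccc(NC(=O)CNc2ccc(C(=O)Nc3ccccc3N)cc2)cc1`) gives 12600 nM, the higher of the two numbers and therefore the weaker inhibitor of growth of the pair. Among the measured compounds shown here, the only measured step is an 11-fold higher number from compound 1 to compound 2 (1.06 log units; beyond the scatter), which is large and beyond the scatter, with 4-methylphenyl in place of 3-nitrophenyl on an amide-type nitrogen. Compound 3 (`COc1ccc(NC(=O)CNc2ccc(C(=O)Nc3ccccc3N)cc2)cc1`) has methoxy in place of methyl on an aromatic carbon, para to a large group: methoxy in place of methyl on an aromatic carbon. The measured step also involves 4-methylphenyl, yet it exchanges a different pair of groups and sets no firm size for this change. In this assay no shift beyond the scatter is expected, with at most a slight lean towards a lower number. The expected step is a 1.3-fold lower number from compound 2 to compound 3 (0.10 log units; within the scatter). For compound 3 the estimated value is 10000 nM, with an expected range of 3500 nM to 25000 nM.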

Compound 3, concentration for 50% growth inhibition: 7500 nM
For compound 3 the middle estimate is 1.3-fold (0.12 log units) above the measured one, and the stated range covers the measured number.
By their numbers in this assay, from the lowest: compound 1; then compounds 3 and 2 (each within the scatter of the next).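

In this assay, methoxy in place of methyl on the aromatic carbon, para to a large group, gives a 1.7-fold lower number from compound 2 to compound 3 (0.23 log units; within the scatter), so this exchange at this position cannot be told apart from the scatter. Compound 1 also stays clear of the new 4-methoxyphenyl compound, with a 6.8-fold higher number from compound 1 to compound 3 (0.83 log units; beyond the scatter), so the gap seen before with 4-methylphenyl is now seen with a second group in place of 3-nitrophenyl. Nothing available explains either step.

The compounds shown leave open whether an amine or a carboxylic acid in place of the methoxy would move the number beyond the scatter. It also stays open whether the standing of compound 1 belongs to the nitro group itself or to where it sits, as compound 1 is the only compound shown that carries one.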